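Swapping Bromine for Fluorine on the Benzyl Group

A few compounds are considered here, and "the series" means these few. Any claim that something is new, unique, unknown or untested is made for them only; others in the source may bear on it.

Compound 1, `CCCCC#Cc1nc(N)c2ncn([C@@H]3OC[C@@H](O)[C@H]3O)c2n1`: 138 nM
Compound 2, `CCCCC#Cc1nc(NCc2cccc(Br)c2)c2ncn([C@@H]3OC[C@@H](O)[C@H]3O)c2n1`: 67 nM
Compound 3, `CCCCC#Cc1nc(NCc2cccc(Br)c2)c2ncn([C@@H]3SC[C@@H](O)[C@H]3O)c2n1`: 24 nM

In an assay on CHO cells for displacement of a labelled ligand from adenosine receptor A3 (Homo sapiens), with a stated time of 60 min (a higher number here means a weaker inhibitor, a lower number a stronger inhibitor), compound 2 gives 67 nM, which places it second highest of the three numbers. Its nearest neighbour is compound 1, reached through a 2.1-fold lower number from compound 1 to compound 2 (0.31 log units; beyond the scatter), and the furthest is compound 3, reached through a 2.8-fold lower number from compound 2 to compound 3 (0.45 log units; beyond the scatter).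

Compound 4, `CCCCC#Cc1nc(NCc2cccc(F)c2)c2ncn([C@@H]3OC[C@@H](O)[C@H]3O)c2n1`, differs from compound 2 by fluoro in place of bromo on an aromatic carbon. Neither measured step touches the halogen on that ring: the step from compound 1 to compound 2 adds the whole 3-bromobenzyl group, and the step from compound 2 to compound 3 changes the sugar-like ring. So no measured step bears directly on this swap. Among the compounds with values here, the only guidance is that the benzyl group as a whole brought a modest gain, so replacing one halogen by another is expected to move the number little, likely within the scatter, with a slight lean toward a weaker inhibitor.

Compound 4 is therefore estimated at 100 nM, with a range from 40 nM to 250 nM. This estimate amounts to an expected step of a 1.5-fold higher number from compound 2 to compound 4 (0.17 log units; within the scatter).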

Compound 4, inhibition constant: 570 nM
Compound 4: the middle estimate sits 5.7-fold (0.76 log units) below what was measured; the measured number lies above the stated range.
By their numbers in this assay, from the lowest: compound 3; then compound 2; then compound 1; then compound 4.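

Swapping one halogen atom for another on the benzyl ring is far from a minor change here, since in this assay it gives an 8.5-fold higher number from compound 2 to compound 4 (0.93 log units; beyond the scatter) even though the heavy-atom count stays the same. The benzyl group is also no gain in itself: 3-bromobenzyl lowered the number, whereas 3-fluorobenzyl gives a 4.1-fold higher number from compound 1 to compound 4 (0.62 log units; beyond the scatter) and so leaves compound 4 a weaker inhibitor than the unsubstituted amine of compound 1. Nothing shown here explains why these two halogens behave so differently.

Chloro, iodo or methyl in the same place on the ring would show whether bromo is a special case or one point in a wider trend. From the compounds shown here alone, it also remains open whether the fluoro swap would cost as much alongside the 3,4-dihydroxythiolan-2-yl group of compound 3.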